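The compounds below may be only part of what the source reports. "The series", "measured", "known", "first", "only" and "open" are said of these compounds alone.

The series shares one core, seen in compound 1 `C=CC(=O)Nc1ccc(-c2nc(Cl)cc(Nc3ccc(C(=O)Nc4ccc(OC)cc4)cc3)n2)cc1`, compound 2 `C=CC(=O)Nc1ccc(-c2nc(Cl)cc(Nc3ccc(C(=O)N4CCCC4)cc3)n2)cc1` and compound 3 `C=CC(=O)Nc1ccc(-c2nc(Cl)cc(Nc3ccc(C(=O)Nc4ccc(F)cc4)cc3)n2)cc1`. In a functional assay on Raji cells (Homo sapiens) for antiproliferative activity, read by MTT assay, with a stated time of 48 h (a lower number here means a stronger inhibitor, a higher number a weaker inhibitor), compound 2 gives 19200 nM. In this assay compound 3 gives "not determined" (no result reported), and compound 1 gives "not determined" (no result reported), so compound 3 stands without a measured position. Compound 4 `C=CC(=O)Nc1ccc(-c2nc(Cl)cc(Nc3ccc(C(=O)Nc4cc(C)ccc4C)cc3)n2)cc1` carries 2,5-dimethylphenyl in place of 4-fluorophenyl on an amide-type nitrogen. For the measured compounds named here, with no measured step between the two aryl amides and only compound 2 giving a number in this assay, the change from compound 3 to compound 4 is expected to lie within the scatter rather than beyond it. On that basis compound 4 is estimated at 9000 nM in this assay, between 1500 nM and 45000 nM.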

Compound 4, half-maximal inhibitory concentration: 20900 nM
Beside the measured number, compound 4's estimate is 2.3-fold (0.37 log units) below it, within the range that was stated.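

In this assay, the step of a 1.1-fold higher number from compound 2 to compound 4 (0.04 log units; within the scatter) lies within the scatter, so at this position on the carbonyl carbon, (2,5-dimethylphenyl)amino and pyrrolidin-1-yl cannot be told apart. Steps involving compound 1 or compound 3 cannot be read. No measurement shown here offers an explanation for this result.

Going by these compounds, it remains open whether the 4-fluorophenyl or 4-methoxyphenyl amides would fall within the same scatter. Also open, on these data alone, is whether a carboxylic acid or a basic amine on this carbonyl carbon would give a step beyond it.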